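One Methyl Addition, Repeated Across Two Related Cores

This account rests on a few compounds, and the source may have more. Where it says the series, first, only, none or still open, it means among the compounds named here.

Measured compounds:
- Compound 1, `CCc1cc(=O)c2ccc(Sc3cccc(Cl)[n+]3[O-])cc2o1`, gives > 29900 nM in a functional assay on KB cells (Homo sapiens) for antiproliferative activity, read by sulforhodamine B assay, with a stated time of 72 h; a higher number here means a weaker inhibitor of growth, a lower number a stronger inhibitor of growth; this value is a limit of the assay, not a number.
- Compound 2, `CCc1cc(=O)c2ccc(Sc3cccc(Cl)[n+]3[O-])c(C)c2o1`, gives > 28700 nM in this assay; this too is a limit.
- Compound 3, `CCc1cc(=O)c2ccc(Sc3cccc(Cl)n3)cc2o1`, gives > 31400 nM in this assay; again a limit.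

Compound 1 and compound 2 differ by one change: methyl in place of hydrogen on an aromatic carbon. The step that the two limits leave unreadable from compound 1 to compound 2 cannot be sized, because both compounds sit at limits, the limit of > 29900 nM in this assay, at which 1 of the 3 values shown sits, and (the limit of > 28700 nM in this assay, at which 1 of the 3 values shown sits). Compound 3 rests at a limit as well, (the limit of > 31400 nM in this assay, at which 1 of the 3 values shown sits), so none of the three gives a readable number.

Compound 3 and compound 1 carry different cores; the difference between the two cores is not broken down here. Compound 4, `CCc1cc(=O)c2ccc(Sc3cccc(Cl)n3)c(C)c2o1`, is not yet measured. It differs from compound 3 by methyl in place of hydrogen on an aromatic carbon. Within the data shown here, this is the same kind of change as the one from compound 1 to compound 2, though the surroundings are not identical: in compound 3 the methyl enters ortho to a group of 8 heavy atoms, whereas in compound 1 it enters ortho to a group of 9 heavy atoms.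

Because compound 3 gives > 31400 nM and the same kind of change left compound 2 at a limit, compound 4 is expected to remain at a limit too, with an estimated step that the limit leaves unreadable from compound 3 to compound 4. Compound 4 is therefore estimated at 40000 nM, between 10000 nM and 150000 nM.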

Compound 4, concentration for 50% growth inhibition: > 30100 nM
Compound 4 ended at the assay's limit; the forecaster's own chance of this, stated with the estimate: 85%; the middle value is on the limit's open side.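

In this assay compound 4 gives > 30100 nM and this is a limit, not a number. Compound 3 also rests at a limit, so the methyl step between compound 3 and compound 4 cannot be read. The compounds shown leave open whether methyl in place of hydrogen on an aromatic carbon changes growth inhibition at all on either core, and how these four compounds would rank.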